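The compounds below may be only part of what the source reports. "The series", "measured", "known", "first", "only" and "open" are said of these compounds alone.

Working notes on the series.

Of the compounds shown here, two have a number so far. Compound 1 `Brc1cccc2c1nnn2CC1CCCC1` gives 7.9 mL/min/g in an ADME assay on microsomes from liver (Homo sapiens) for metabolic stability, tested at 2.5 uM; a higher number here means faster removal of the compound, a lower number slower removal. Compound 2 `Brc1cccc2c1nnn2CC1CC1` gives 1.3 mL/min/g in this assay. Among the compounds with values here, the one step between them, a 6.1-fold lower number from compound 1 to compound 2 (0.78 log units; beyond the scatter), is cyclopropyl in place of cyclopentyl on a saturated chain carbon bound to an aromatic nitrogen. On the two numbers shown, compound 2 stands lowest; its nearest neighbour is compound 1, whose number is higher by that same step, beyond the scatter.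

Compound 3 `CCCCn1nnc2c(Br)cccc21` has not been measured. It differs from compound 2 as follows: propyl in place of cyclopropyl on a saturated chain carbon bound to an aromatic nitrogen. Within the data shown here, the only measured step that bears on this change is a 6.1-fold lower number from compound 1 to compound 2 (0.78 log units; beyond the scatter), which swapped one ring for another at the same place and was modest; here a ring gives way to an open chain of the same count, so the comparison is indirect. The step from compound 2 to compound 3 is expected to be a 1.9-fold higher number from compound 2 to compound 3 (0.28 log units; within the scatter), a rise that may or may not clear the scatter. Compound 3 is therefore estimated at 2.5 mL/min/g in this assay, with a range from 1 mL/min/g to 6.5 mL/min/g.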

Compound 3, intrinsic clearance in a liver preparation (reported as CLH), per the amount of preparation that the assay uses: 9.5 mL/min/g
Estimate against measurement, compound 3: 3.8-fold (0.58 log units) below, outside the stated range (above it).
By their numbers in this assay, from the lowest: compound 2; then compounds 1 and 3 (each within the scatter of the next).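

At this place, on a saturated chain carbon bound to an aromatic nitrogen, propyl in place of cyclopropyl gives a 7.3-fold higher number from compound 2 to compound 3 (0.86 log units; beyond the scatter) in this assay, although the two groups hold the same count of heavy atoms, so that count alone does not set the number among these compounds. Propyl in place of cyclopentyl gives a 1.2-fold higher number from compound 1 to compound 3 (0.08 log units; within the scatter), which puts the open chain and the larger ring level, so the earlier step no longer reads as a simple trend with ring size, and of the three groups only cyclopropyl carries the low number. No measurement in hand accounts for this difference.

From the compounds shown here alone, whether the low number belongs to cyclopropyl alone or extends to other small rings stays open, and so does how far it depends on the ring as such rather than on the branching of the group. Cyclobutyl, isopropyl or a chain carrying an ether oxygen or an amine at this place would bear on both questions in this assay.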